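The compounds below may be only part of what the source reports. "The series", "measured", "known", "first", "only" and "open" are said of these compounds alone.

Compound 1, `CCCC(O)CC(=O)O[C@H](CC=C(C)C)C1=CC(=O)c2c(O)ccc(O)c2C1=O` — in a functional assay on DU-145 cells (Homo sapiens) for cytotoxicity, read by MTT assay (on this read-out lower numbers stand for stronger inhibition and higher numbers for weaker inhibition), compound 1 gives > 100000 nM, which is a limit of the assay and not a number.
Compound 2, `CCCC(CC(=O)O[C@H](CC=C(C)C)C1=CC(=O)c2c(O)ccc(O)c2C1=O)OC(C)=O` — in this assay compound 2 gives 55700 nM.

Among the compounds with values here, compound 1 stands at the limit of > 100000 nM in this assay, at which 1 of the 2 values shown sits; of the two measured compounds, it is the only one with no number, so its place on the scale is known only as a limit. Within the data shown here, the one measured step, an at least 1.7-fold lower number from compound 1 to compound 2 (0.25 log units; that floor lies within the scatter), shows that capping the hydroxyl oxygen gave a somewhat lower number, though its floor stays within the scatter.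

Compound 3, `CCC(CO[C@H](CC=C(C)C)C1=CC(=O)c2c(O)ccc(O)c2C1=O)OC`, carries the change (2-methoxybutyl in place of (2-hydroxypentyl)carbonyl on an oxygen on a saturated carbon). Among the measured compounds shown here, as in compound 2, the free hydroxyl of compound 1 is gone, so the step from compound 1 to compound 2 is the only guide, and it is small. Compound 3 is therefore expected to show an at least 1.6-fold lower number from compound 1 to compound 3 (0.22 log units; that floor lies within the scatter), at most a modest change from compound 1 in this assay. Compound 3 is estimated at 60000 nM, within 20000 nM to 200000 nM.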

Compound 3, half-maximal inhibitory concentration: 45700 nM
Beside the measured number, compound 3's estimate is 1.3-fold (0.12 log units) above it; the measured number falls inside the stated range.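

Putting 2-methoxybutyl in place of (2-hydroxypentyl)carbonyl gives an at least 2.1-fold lower number from compound 1 to compound 3 (0.34 log units; beyond the scatter) in this assay. Within the data shown here, this is the first step at this oxygen on a saturated carbon that is read as beyond the scatter, which the acetyl step to compound 2 did not show, and it also shows that a measurable number survives without the carbonyl of the original ester group. The true size of the step stays unknown, as compound 1 has only a limit and the step is therefore a floor: the limit of > 100000 nM in this assay, at which 1 of the 3 values shown sits.

The compounds shown leave open whether an amine, a carboxylic acid or a longer chain on this oxygen would move the number further. They also leave open which part of the change carries the step: the loss of the hydroxyl, the loss of the carbonyl, or the swap of the chain itself.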